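Succinamide amine variant in the nitrobenzoxadiazole thioether series

The source may hold more compounds than are shown below. What is called first, only, known or untested is meant among the compounds shown, and "the series" means these compounds.

Of the compounds shown here, three sharing one core have been measured in an assay on isolated protein for inhibition of glutathione S-transferase P (Homo sapiens), with a stated time of 10 min; on this read-out lower numbers stand for stronger inhibition and higher numbers for weaker inhibition. Compound 1 `O=C(CCC(=O)OCCCCCCSc1ccc([N+](=O)[O-])c2nonc12)Nc1ccccc1F` gives 9890 nM. Compound 2 `O=C(CCC(=O)OCCCCCCSc1ccc([N+](=O)[O-])c2nonc12)Nc1cccc(Cl)c1` gives 28800 nM. Compound 3 `O=C(CCC(=O)OCCCCCCSc1ccc([N+](=O)[O-])c2nonc12)Nc1ccc(Br)cc1` gives 5090 nM, the lowest of the three numbers; its separation from compound 1 lies within the scatter, so no order between the two can be claimed, while the step of a 5.7-fold lower number from compound 2 to compound 3 (0.75 log units; beyond the scatter) is beyond it. The other aryl exchanges show a 2.9-fold higher number from compound 1 to compound 2 (0.46 log units; beyond the scatter) and a 1.9-fold lower number from compound 1 to compound 3 (0.29 log units; within the scatter).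

Compound 4 `CN(C)CCNC(=O)CCC(=O)OCCCCCCSc1ccc([N+](=O)[O-])c2nonc12` is not yet measured. It differs from compound 3 by 2-(dimethylamino)ethyl in place of 4-bromophenyl on an amide-type nitrogen. Going by the values given here, none of the measured steps covers an exchange of an aryl group for an aliphatic amine chain; all three concern a halogenated phenyl in place of another. They therefore set only the spread that substitution at this nitrogen has produced so far, and give no direction for the present change. Among the compounds with values here, with no bearing step, a number near the middle of the measured span is the plainest expectation, with a wide range on either side. For compound 4 in this assay the estimate is 15000 nM, between 3000 nM and 70000 nM, corresponding to an expected step of a 2.9-fold higher number from compound 3 to compound 4 (0.47 log units; beyond the scatter).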

Compound 4, half-maximal inhibitory concentration: 540 nM
Beside the measured number, compound 4's estimate is 28-fold (1.44 log units) above it, and the stated range ends above it.
By their numbers in this assay, from the lowest: compound 4; then compounds 3 and 1 (each within the scatter of the next); then compound 2.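

In this assay, 2-(dimethylamino)ethyl on the amide-type nitrogen gives a 9.4-fold lower number from compound 3 to compound 4 (0.97 log units; beyond the scatter), and the same kind of exchange gives an 18-fold lower number from compound 1 to compound 4 (1.26 log units; beyond the scatter) and a 53-fold lower number from compound 2 to compound 4 (1.73 log units; beyond the scatter). Compound 4 therefore has the lowest number of the four, with all three of its steps beyond the scatter, so a phenyl ring on this nitrogen is not required for inhibition in this series. The earlier compounds shown here showed only exchanges among halogenated phenyl groups, the largest being a 5.7-fold lower number from compound 2 to compound 3 (0.75 log units; beyond the scatter), while the steps to compound 4 show that a group with no ring can move the number further than any of those exchanges did.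

Nothing shown here accounts for the size or the direction of this change. Still open, as far as these compounds go, is whether the dimethylamino nitrogen or simply the loss of the aryl ring carries the result, which could be separated by a plain alkyl chain of similar length, a 2-methoxyethyl group, a longer chain ending in the same amine, or a carboxylic acid at the end of the chain.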